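Notes on a tolerated-concentration series at the amine nitrogen

A few compounds are considered here, and "the series" means these few. Any claim that something is new, unique, unknown or untested is made for them only; others in the source may bear on it.

Compound 1 `Cc1ccc2[nH]c(=O)c(CN(Cc3ccc(C(N)=O)cc3)Cc3ccc(C(C)(C)C)cc3)cc2c1`: in a toxicity assay on MDCK cells (Canis lupus familiaris) for cytotoxicity, read by crystal violet staining, with a stated time of 48 h (a lower number here means that less compound is tolerated, a higher number that more compound is tolerated), compound 1 gives > 5000 nM, which is a limit of the assay and not a number.
Compound 2 `Cc1ccc2[nH]c(=O)c(CN(Cc3ccc(C(C)(C)C)cc3)C(C)c3ccc(N(C)C)c(Cl)c3)cc2c1`: in this assay compound 2 gives 9800 nM.

Compound 2 holds the only number shown; the other value is a limit, (the limit of > 5000 nM in this assay, at which 1 of the 2 values shown sits). The step that the limit leaves unreadable from compound 1 to compound 2 is therefore left unreadable. Compound 3 `COc1ccc(C(C)N(Cc2ccc(C(C)(C)C)cc2)Cc2cc3cc(C)ccc3[nH]c2=O)cc1Cl` differs from compound 2 by methoxy in place of dimethylamino on an aromatic carbon. Among the measured compounds shown here, no measured step bears on this change, so the expected step of no change at the digits printed from compound 2 to compound 3 (within the scatter) is none beyond the scatter. Compound 3 is estimated at 9800 nM in this assay, expected to fall between 4000 nM and 25000 nM.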

Compound 3, half-maximal cytotoxic concentration: > 10000 nM
Compound 3 gave a limit, no number; the forecaster's own chance of this, stated with the estimate: 25%; at least 1.0-fold (0.00 log units) between middle value and limit.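

Compound 3 stands at a limit of the assay, not a number, in this assay: the limit of > 10000 nM in this assay, at which 1 of the 3 values shown sits.
Methoxy in place of dimethylamino on this aromatic carbon, ortho to the chloro group, gives an at least 1.0-fold higher number from compound 2 to compound 3 (0.00 log units; that floor lies within the scatter), so the loss of dimethylamino shows no fall in the tolerated concentration, though the floor of that step cannot separate it from no change. The step between compound 1 and compound 3 cannot be read.

Going by these compounds, whether the true step from dimethylamino to methoxy lies beyond the scatter remains open. On these data alone, how a hydroxyl or a primary amine at this carbon would read also remains open.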